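Sulfamide Piperidines: Aryl Substituent and Growth Inhibition

The source may report more compounds than this note shows. Statements on the series, on what has been measured and on what is new or still open speak of the compounds shown alone.

The measured compounds and their values:
compound 1, `CC(C)(C)c1ccc(-c2cc(N3CCC(CNS(N)(=O)=O)CC3)ncn2)cc1`: 19700 nM
compound 2, `COc1ccc(-c2cc(N3CCC(CNS(N)(=O)=O)CC3)ncn2)cc1`: 35300 nM
compound 3, `CCOC(=O)c1ccc(-c2cc(N3CCC(CNS(N)(=O)=O)CC3)ncn2)cc1`: 4100 nM

In a functional assay on MCF7 cells (Homo sapiens) for antiproliferative activity, read by sulforhodamine B assay, with a stated time of 48 h (a higher number here means a weaker inhibitor of growth, a lower number a stronger inhibitor of growth), compound 2 gives the highest of the three numbers. Its nearest neighbour is compound 1, and the step of a 1.8-fold higher number from compound 1 to compound 2 (0.25 log units; within the scatter) lies within the scatter. The step of an 8.6-fold lower number from compound 2 to compound 3 (0.93 log units; beyond the scatter) lies beyond it, as does a 4.8-fold lower number from compound 1 to compound 3 (0.68 log units; beyond the scatter).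

Compound 4, `NS(=O)(=O)NCC1CCN(c2cc(-c3ccccc3F)ncn2)CC1`, differs from compound 2 in one place: 2-fluorophenyl in place of 4-methoxyphenyl on an aromatic carbon. Among the compounds with values here, no measured step tells how a 2-fluorophenyl behaves here. The two steps that touch compound 2 show that exchanging the group on the phenyl ring can leave the number where it is or lower it by a modest amount, and none raises it. From the compounds shown here alone, the expectation for compound 4 is therefore a small step down or none beyond the scatter, with a wide range because the new group is untested.

Compound 4 is expected to give 22000 nM in this assay, between 6000 nM and 70000 nM, corresponding to a 1.6-fold lower number from compound 2 to compound 4 (0.21 log units; within the scatter).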

Compound 4, concentration for 50% growth inhibition: 48500 nM
Estimate against measurement, compound 4: 2.2-fold (0.34 log units) below; low and high end bracket the measured number.
By their numbers in this assay, from the lowest: compound 3; then compounds 1, 2 and 4 (each within the scatter of the next, the first and the last beyond it).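

In this assay the step of a 1.4-fold higher number from compound 2 to compound 4 (0.14 log units; within the scatter) shows that this position accepts 2-fluorophenyl in place of 4-methoxyphenyl with no change that can be read, even though the entering group differs in its ring substituent and has no hydrogen-bond acceptor. Within the data shown here, the first aryl group with a fluorine thus stays with the two weaker compounds, and only compound 3 stands apart, at 4100 nM in this assay. Nothing measured here explains why these groups give such similar numbers.

The compounds shown leave open whether the lower number of compound 3 belongs to the ethoxycarbonyl group itself, as neither a carboxylic acid nor a primary amide on the phenyl ring appears among them. Also open, from the compounds shown here alone, is how an unsubstituted phenyl or a 4-fluorophenyl would compare with 2-fluorophenyl.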